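The compounds below may be only part of what the source reports. "The series", "measured", "known", "first", "only" and "open" are said of these compounds alone.

Measured in a functional assay on HEK293 cells for activation of melanin-concentrating hormone receptor 1 (Homo sapiens), read by inositol phosphate accumulation; on this read-out lower numbers stand for an effect already at smaller amounts and higher numbers for an effect only at larger amounts of compound:
compound 1 `Nc1cc(C2CCCC2)nc2ccc(NC(=O)/C=C/c3ccc(C(F)(F)F)cc3)cc12`, 68 nM
compound 2 `CCCCc1ccc(/C=C/C(=O)Nc2ccc3nc(CCC)cc(N)c3c2)cc1`, 740 nM
compound 3 `CCCc1cc(N)c2cc(NC(=O)/C=C/c3ccc(Cl)c(Cl)c3)ccc2n1`, 990 nM

Compound 1 stands at the lowest number of the three in this assay. Compound 2 and compound 3 both lie beyond the scatter above it, compound 2 the nearer of the two and compound 3 the farther. Both of them differ from compound 1 in more than one place, so their gaps to compound 1 cannot be tied to any single group.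

Compound 4 `CCC(C)c1cc(N)c2cc(NC(=O)/C=C/c3ccc(C(F)(F)F)cc3)ccc2n1` has not yet been measured in this assay. It keeps the cinnamamide with its trifluoromethyl from compound 1 and changes the core in one place: sec-butyl in place of cyclopentyl on an aromatic carbon. Among the measured compounds shown here, no measured pair differs in this place alone, so the step has no direct precedent. Compound 2 and compound 3 carry a propyl group where compound 1 carries cyclopentyl, but they also differ elsewhere, so they give only a loose hint that a smaller open-chain group goes with a higher number. The step from compound 1 to compound 4 is therefore expected to be small and upward, at most slightly beyond the scatter. Compound 4 is estimated at 150 nM, with a range from 50 nM to 500 nM. The expected step is a 2.2-fold higher number from compound 1 to compound 4 (0.34 log units; beyond the scatter).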

Compound 4, half-maximal effective concentration: 44 nM
The estimate for compound 4 lay 3.4-fold (0.53 log units) above the measured number, outside the stated range (below it).
By their numbers in this assay, from the lowest: compounds 4 and 1 (each within the scatter of the next); then compounds 2 and 3 (each within the scatter of the next).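

In this assay, among the compounds shown here, sec-butyl in place of cyclopentyl on the aromatic carbon next to the ring nitrogen gives a 1.5-fold lower number from compound 1 to compound 4 (0.19 log units; within the scatter), the first reading of this position with everything else in the molecule held constant. With the trifluoromethyl cinnamamide and the amino group kept, the five-membered non-aromatic ring can therefore give way to an open-chain branched group without a step beyond the scatter, so a closed ring is not needed here for a number of this order. No measurement on hand accounts for the two groups lying within the scatter of each other, and the step alone gives no explanation for it.

The compounds shown do not tell how far this tolerance extends, since only these two carbon-only groups are compared directly at this position with the trifluoromethyl cinnamamide in place. Propyl with that same cinnamamide, a longer chain such as n-hexyl, a smaller group such as methyl, a phenyl ring, or a group carrying oxygen or nitrogen such as methoxymethyl or an amine on this carbon all remain open.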